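The compounds below may be only part of what the source reports. "The series", "measured", "known", "first", "only" and "open" are said of these compounds alone.

Measured compounds:
- compound 1 `C=C1CC[C@@H]2[C@](C)(COC(C)=O)[C@H](OC(C)=O)CC[C@@]2(C)[C@H]1CC(Nc1ccc(S(=O)(=O)Nc2ccc(Cl)nn2)cc1)C1=CCOC1=O` — in a functional assay on SR cells (Homo sapiens) for inhibition, read by sulforhodamine B assay, with a stated time of 48 h (a higher number here means that more compound is tolerated, a lower number that less compound is tolerated), compound 1 gives > 100000 nM, a limit of the assay.
- compound 2 `C=C1CC[C@@H]2[C@](C)(COC(C)=O)[C@H](OC(C)=O)CC[C@@]2(C)[C@H]1CC(Nc1ccc(S(=O)(=O)Nc2cc(C)on2)cc1)C1=CCOC1=O` — in this assay compound 2 gives > 100000 nM, also a limit of the assay.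

Within the data shown here, compound 2 stands only on a limit, and the one other value is a limit as well. The step that the two limits leave unreadable from compound 1 to compound 2 therefore cannot be read in size or direction; both of its ends sit at the limit of > 100000 nM in this assay, at which 2 of the 2 values shown sit.

Compound 3 `C=C1CC[C@@H]2[C@](C)(COC(C)=O)[C@H](OC(C)=O)CC[C@@]2(C)[C@H]1CC(Nc1ccc(S(=O)(=O)Nc2nccc(C)n2)cc1)C1=CCOC1=O` is the next member of the series. It differs from compound 2 by 4-methylpyrimidin-2-yl in place of 5-methyl-1,2-oxazol-3-yl on a sulfonamide nitrogen. Among the measured compounds shown here, the only measured step that bears on a swap of the heteroaryl group on the sulfonamide nitrogen is the unreadable one from compound 1 to compound 2, which gives no usable size. Nothing in the two measured values points to a change beyond the scatter in this assay, in either direction, for this further swap.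

Working expectation for the step from compound 2 to compound 3 is therefore a number no higher from compound 2 to compound 3 (the limit leaves the size open), that is, no readable change. For compound 3 in this assay the estimate is 100000 nM, with a range from 30000 nM to 300000 nM, and most likely the assay again reports only a limit.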

Compound 3, concentration lethal to 50% of the cells: > 100000 nM
Compound 3: a limit, no number; the forecaster's own chance of this, stated with the estimate: 80%; the middle value lies on the limit itself.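

No step can be read among compound 1, compound 2 and compound 3 in this assay, as all three values are limits of the assay: (the limit of > 100000 nM in this assay, at which 3 of the 3 values shown sit). The compounds shown leave open whether the 6-chloropyridazin-3-yl, 5-methyl-1,2-oxazol-3-yl and 4-methylpyrimidin-2-yl groups on a sulfonamide nitrogen differ at all in this read-out; none of the three gives a number.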